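Replacing Methoxyphenyl with Dichlorophenyl in Compound 1

The source may hold more compounds than are shown below. What is called first, only, known or untested is meant among the compounds shown, and "the series" means these compounds.

Compound 1 `COc1ccc(NC(=O)NCCNS(=O)(=O)c2ccc(-c3ccccc3OCc3ccccc3)s2)cc1`: > 20000 nM
Compound 2 `COc1ccc(Oc2ccc([N+](=O)[O-])cc2-c2ccsc2S(=O)(=O)N2CCN(C(=S)Nc3ccc([N+](=O)[O-])cc3)CC2)cc1OC`: > 50000 nM

In a functional assay on RS4-11 cells (Homo sapiens) for inhibition, read by CCK-8 assay, with a stated time of 48 h (a lower number here means a stronger inhibitor, a higher number a weaker inhibitor), compound 1 gives > 20000 nM, which is a limit of the assay rather than a measured number (the limit of > 20000 nM in this assay, at which 1 of the 2 values shown sits). Compound 2 likewise shows only a limit, > 50000 nM (the limit of > 50000 nM in this assay, at which 1 of the 2 values shown sits). Within the data shown here, no step between measured compounds exists here. Compound 3 `O=C(NCCNS(=O)(=O)c1ccc(-c2ccccc2OCc2ccccc2)s1)Nc1cc(Cl)cc(Cl)c1` differs from compound 1 by one change: 3,5-dichlorophenyl in place of 4-methoxyphenyl on an amide-type nitrogen. Among the measured compounds shown here, both measured compounds sit at limits, so no measured step gives a direction. The step expected from compound 1 to compound 3 in this assay is a step that the limit leaves unreadable from compound 1 to compound 3, meaning no change beyond the scatter. Compound 3 is expected to give about 30000 nM, within 8000 nM to 100000 nM, most likely reported again as a limit.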

Compound 3, half-maximal inhibitory concentration: > 20000 nM
Compound 3 gave a limit, no number; the forecaster's own chance of this, stated with the estimate: 75%; the middle value is on the limit's open side.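

Among these compounds, compound 1 and compound 3 both end at a limit in this assay, and no step between them can be read. The compounds shown leave open how strongly either one inhibits, and whether 3,5-dichlorophenyl in place of 4-methoxyphenyl changes that at all.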